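This account rests on a few compounds, and the source may have more. Where it says the series, first, only, none or still open, it means among the compounds named here.

Measured so far in an in vitro ADME assay on microsomes from liver (Homo sapiens) for pharmacokinetics; on this read-out higher numbers stand for fast clearance and lower numbers for slow clearance:
Compound 1 `CN(C)CCN1CCN(c2ccc(Cn3c(=O)[nH]c4c(N)nc(C(F)(F)F)cc43)cn2)CC1` gives < 8 mL.min-1.g-1, a limit of this assay rather than a number.
Compound 2 `CCN(CC)CCN(C)c1ccc(Cn2c(=O)[nH]c3c(N)nc(C(F)(F)F)cc32)cn1` gives 24 mL.min-1.g-1.

Compound 1 therefore stands at the limit of < 8 mL.min-1.g-1 in this assay, at which 1 of the 2 values shown sits, the slow end of what is shown. Compound 3 `CN1CCN(CCN(C)c2ccc(Cn3c(=O)[nH]c4c(N)nc(C(F)(F)F)cc43)cn2)CC1` differs from it by methyl(2-(4-methylpiperazin-1-yl)ethyl)amino in place of 4-(2-(dimethylamino)ethyl)piperazin-1-yl on an aromatic carbon. Going by the values given here, the only measured step that bears on this change is an at least 3.0-fold higher number from compound 1 to compound 2 (0.47 log units; beyond the scatter), where the ring of compound 1 was opened into the chain seen in compound 2. Compound 3 keeps a six-membered non-aromatic ring with 2 hetero atoms while gaining the methyl-bearing amino chain of compound 2, so a rise smaller than that step is expected. For compound 3 the expected value is 13 mL.min-1.g-1, within 6 mL.min-1.g-1 to 28 mL.min-1.g-1. This expectation corresponds to a step of an at least 1.6-fold higher number from compound 1 to compound 3 (0.21 log units; that floor lies within the scatter).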

Compound 3, intrinsic clearance in microsomes in the Homo sapiens assay: 25 mL.min-1.g-1
The estimate for compound 3 lay 1.9-fold (0.28 log units) below the measured number, and the stated range covers the measured number.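

In the Homo sapiens assay, rearranging the same atoms from 4-(2-(dimethylamino)ethyl)piperazin-1-yl into methyl(2-(4-methylpiperazin-1-yl)ethyl)amino gives an at least 3.1-fold higher number from compound 1 to compound 3 (0.49 log units; beyond the scatter), so keeping a six-membered non-aromatic ring does not by itself hold the number down. Placing 4-methylpiperazin-1-yl instead of diethylamino on a saturated chain carbon gives a 1.0-fold higher number from compound 2 to compound 3 (0.02 log units; within the scatter), so this swap shows no clear effect. In a physicochemical assay for lipophilicity (on this read-out higher numbers stand for higher lipophilicity and lower numbers for lower lipophilicity), compound 1 gives 0.9 and compound 3 gives 1.5. Lipophilicity shifts with the rearrangement, which may contribute to the rise in the Homo sapiens assay, as seen in the physicochemical assay: the measured distribution coefficient of compound 1, 0.9, and of compound 3, 1.5, a number 0.60 log units higher (beyond the scatter)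

Going by these compounds, the value for compound 1 is a limit, so the full size of its steps stays unknown. On these data alone, whether morpholine in place of 4-methylpiperazin-1-yl, or a longer chain, would keep the number of compound 3 also stays open.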